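This account rests on a few compounds, and the source may have more. Where it says the series, first, only, none or still open, it means among the compounds named here.

In a functional assay on HCT-116 cells (Homo sapiens) for antiproliferative activity, read by MTT assay, with a stated time of 72 h (on this read-out lower numbers stand for stronger inhibition and higher numbers for weaker inhibition), compound 1 `O=C(CSc1cccc(O)c1)Nc1ccc2nc(NC(=O)c3ccccc3)sc2c1` gives 41000 nM. That is the higher of the two true numbers available, so compound 1 is a weak starting point. Compound 3 `Nc1ccc(SCC(=O)Nc2ccc3nc(NC(=O)c4ccc(C(F)(F)F)cc4)sc3c2)cc1` gives 100 nM, far lower than compound 1, and this gap lies well beyond the scatter of repeat measurements. Compound 2 `Cn1c(CNC(=O)c2cccs2)nnc1SCC(=O)Nc1cccc(Cl)c1` reads > 100000 nM, which is a limit of the assay and not a number.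

The next compound to be tested, compound 4 `Cc1cc(C)cc(C(=O)Nc2nc3ccc(NC(=O)CSc4cccc(O)c4)cc3s2)c1`, keeps the rest of compound 1 and alters a single group: 3,5-dimethylphenyl in place of phenyl on a carbonyl carbon. Put simply, 3,5-dimethylphenyl replaces phenyl on a carbonyl carbon that also carries an amide-type nitrogen.

Within the data shown here, no measured pair of compounds isolates this kind of change, so the forecast is necessarily loose. The main guide is compound 3 at 100 nM, which shows that numbers far lower than that of compound 1 can be reached with compounds of this kind. A swap of one group is still not expected to cover much of that distance. In this assay, a modest move toward stronger inhibition is expected, an estimated 2.7-fold lower number from compound 1 to compound 4 (0.44 log units; beyond the scatter). For compound 4 the expected value is 15000 nM, with an estimated range from 2500 nM to 70000 nM.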

Compound 4, half-maximal inhibitory concentration: 5130 nM
Estimate against measurement, compound 4: 2.9-fold (0.47 log units) above; the measured number falls inside the stated range.
By their numbers in this assay, from the lowest: compound 3; then compound 4; then compound 1. At a limit, above all of these: compound 2.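

Among these compounds, until now, no pair of compounds isolated a change on this carbonyl carbon, so it was unknown whether the number would respond to a change in the ring held there. In this assay, 3,5-dimethylphenyl in place of phenyl gives an 8.0-fold lower number from compound 1 to compound 4 (0.90 log units; beyond the scatter), which shows that this place responds to a change that leaves the rest of the molecule untouched. The entering group adds only carbon and leaves the counts of hydrogen-bond donors and acceptors at zero, so a lower number here required no new donor or acceptor, but nothing measured here says why the number falls.

Among the compounds shown here, with only this one pair, it remains open whether both methyl groups of 3,5-dimethylphenyl are needed or whether a single methyl group would give a similar step. On these data alone, it also remains open how this ring would behave with other groups in place of methyl, such as methoxy, chlorine or an amine, and whether the same swap would lower the number in a compound with a different group on the sulfur atom.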